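Pyrazine amide in place of pyrimidine urea on a quinolinone core

The source may hold more compounds than are shown below. What is called first, only, known or untested is meant among the compounds shown, and "the series" means these compounds.

Measured compounds:
- compound 1 `Cc1cc(C)cc(-c2c(O)nc3cc(Cl)c(NC(=O)c4cnccn4)cc3c2OCCC2CCCCN2)c1`: 10 nM
- compound 2 `Cc1cc(C)cc(-c2c(O)nc3cc(Cl)c(NC(=O)Nc4cncnc4)cc3c2OCC[C@@H]2CCCCN2)c1`: 57 nM
- compound 3 `O=C(Nc1ccncn1)c1cc2c(OCC[C@@H]3CCCCN3)c(-c3ccc(Cl)c(Cl)c3)c(O)nc2cc1Cl`: 1 nM

In an assay on isolated protein for inhibition of Gonadotropin-releasing hormone receptor (Homo sapiens) (on this read-out lower numbers stand for stronger inhibition and higher numbers for weaker inhibition), compound 2 gives the highest number of the three, so it is the weakest inhibitor among them; compound 1 sits well beyond the scatter below it, and compound 3 further still. Compound 4 `Cc1cc(C)cc(-c2c(O)nc3cc(Cl)c(NC(=O)c4cnccn4)cc3c2OCC[C@@H]2CCCCN2)c1` differs from compound 2 by pyrazin-2-yl in place of (pyrimidin-5-yl)amino on a carbonyl carbon. Compound 1 already carries this same pyrazin-2-yl carbonyl group and gives 10 nM, differing from compound 4 only in how the piperidine stereocentre is specified. On that basis a clear step towards stronger inhibition is expected, a 7.1-fold lower number from compound 2 to compound 4 (0.85 log units; beyond the scatter), well beyond the scatter. Compound 4 is therefore estimated at 8 nM, with a likely range from 3 nM to 25 nM.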

Compound 4, half-maximal inhibitory concentration: 2 nM
For compound 4 the middle estimate is 4.0-fold (0.60 log units) above the measured one; measured number outside the range, below it.
By their numbers in this assay, from the lowest: compounds 3 and 4 (each within the scatter of the next); then compound 1; then compound 2.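

In this assay, putting pyrazin-2-yl in place of (pyrimidin-5-yl)amino on a carbonyl carbon gives a 29-fold lower number from compound 2 to compound 4 (1.45 log units; beyond the scatter), so this position responds strongly to the change, which also removes a hydrogen-bond donor. A second step, a 5.0-fold lower number from compound 1 to compound 4 (0.70 log units; beyond the scatter), joins two structures with the same atoms and bonds, so it can be traced to a single feature: the fact that one of compounds 1 and 4 is drawn with a defined configuration and the other without, at the place where they differ

The swap changes the ring and the linking nitrogen together, so their separate contributions remain unclear. From the compounds shown here alone, it also remains open how a plain phenyl or pyridin-2-yl on the carbonyl would compare, and how the R configuration at the stereocentre would read.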